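Cyclopropyl in Place of Ethyl in an Aryl Ether Chain

The source may report more compounds than this note shows. Statements on the series, on what has been measured and on what is new or still open speak of the compounds shown alone.

Measured so far:
Compound 1, `CCOc1cc(C)c(-c2cccc(COc3ccc(S(=O)(=O)CC(=O)O)cc3)c2)c(C)c1`, gives 2.86 in a physicochemical assay for lipophilicity, using the shake flask method, in phosphate buffer, measured as octanol-water partition, with a stated time of 24 h, at pH 7.4, tested at 100 uM; a lower number here means a more polar compound, a higher number a more lipophilic compound.
Compound 2, `CCCOc1cc(C)c(-c2cccc(COc3ccc(S(=O)(=O)CC(=O)O)cc3)c2)c(C)c1`, gives 3.58 in this assay.

Compound 2 has the highest of the two numbers; its nearest neighbour, compound 1, lies a step below it, a number 0.72 log units higher from compound 1 to compound 2 (beyond the scatter), which is beyond the scatter. The unmeasured compound 3, `Cc1cc(OCC2CC2)cc(C)c1-c1cccc(COc2ccc(S(=O)(=O)CC(=O)O)cc2)c1`, differs from compound 2 by cyclopropyl in place of ethyl on a saturated chain carbon bound to an oxygen on an aromatic ring. For the measured compounds named here, the only measured step, a number 0.72 log units higher from compound 1 to compound 2 (beyond the scatter), concerns a methyl added on that same chain. Compound 3 likewise carries a larger group on that chain than compound 2, here closed into a ring, so that step is the nearest guide to the new change. A rise in this assay of about the same order or smaller is therefore expected, so that the step of a number 0.22 log units higher from compound 2 to compound 3 (within the scatter) is estimated as a modest increase. Compound 3 is thus expected to give 3.8, within a range from 3.4 to 4.2.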

Compound 3, distribution coefficient: 3.46
Beside the measured number, compound 3's estimate is 0.34 log units above it; measured number inside the range.
By their numbers in this assay, from the lowest: compound 1; then compounds 3 and 2 (each within the scatter of the next).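

Read as whole side chains, propoxy and cyclopropylmethoxy cannot be told apart in this assay: replacing ethyl with cyclopropyl on a saturated chain carbon bound to an oxygen on an aromatic ring gives a number 0.12 log units lower from compound 2 to compound 3 (within the scatter), so closing the chain end into a ring produces no readable change here. Replacing methyl with cyclopropyl at the same place gives a number 0.60 log units higher from compound 1 to compound 3 (beyond the scatter), so compound 2 and compound 3 both stand clearly apart from compound 1 but not from each other. No measurement shown here explains why the open chain and the ring read alike.

On these data alone, whether a longer chain such as butyl, or an amine within the chain, would shift the number remains open. So does whether a cyclobutyl group at this place would read like cyclopropyl.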